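Adding Butyl to the Free Piperazine Nitrogen

The compounds below may be only part of what the source reports. "The series", "measured", "known", "first", "only" and "open" are said of these compounds alone.

Compound 1 `CN1CCN(CCCCn2c3c(c4ccccc42)C(=O)c2c[n+]([O-])c4ccccc4c2C3=O)CC1` in a functional assay on MDA-MB-231 cells (Homo sapiens) for cytotoxicity, read by MTT assay, with a stated time of 72 h (on this read-out higher numbers stand for weaker inhibition and lower numbers for stronger inhibition), gives 110 nM
Compound 2 `O=C1c2c[n+]([O-])c3ccccc3c2C(=O)c2c1c1ccccc1n2CCCCN1CCNCC1` in this assay gives 3310 nM

Compound 2 stands highest of the two at 3310 nM in this assay and is the starting point here. Compound 3 `CCCCN1CCN(CCCCn2c3c(c4ccccc42)C(=O)c2c[n+]([O-])c4ccccc4c2C3=O)CC1` differs from it by butyl in place of hydrogen on an amine nitrogen in a ring and so carries butyl in place of hydrogen on an amine nitrogen in a ring. For the measured compounds named here, one measured step bears on this: a 30-fold higher number from compound 1 to compound 2 (1.48 log units; beyond the scatter) is large and concerns the same nitrogen, with hydrogen in place of methyl. Read in reverse, it points toward a lower number when that hydrogen is replaced. Going by the values given here, no measured compound carries butyl there, so the size remains uncertain. A large step toward a lower number is expected, possibly short of the measured one. The expected step is a 13-fold lower number from compound 2 to compound 3 (1.12 log units; beyond the scatter) by this estimate. For compound 3 the estimated value is 250 nM with an expected range of 60 nM to 1000 nM in this assay.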

Compound 3, half-maximal inhibitory concentration: 900 nM
Estimate against measurement, compound 3: 3.6-fold (0.56 log units) below; the measured number falls inside the stated range.
By their numbers in this assay, from the lowest: compound 1; then compound 3; then compound 2.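

In this assay, butyl on this ring nitrogen also gives a lower number than the free nitrogen of compound 2 (a 3.7-fold lower number from compound 2 to compound 3 (0.57 log units; beyond the scatter)), so the gain is not confined to methyl, the only substituent seen there before. Butyl does not recover all of that gain, however: the pair of substituted compounds shows a further gap (an 8.2-fold higher number from compound 1 to compound 3 (0.91 log units; beyond the scatter)), which means the identity of the group on this nitrogen matters as well as the loss of the hydrogen. Nothing in the data available here accounts for this order.

With only methyl and butyl on this nitrogen, the compounds shown do not establish how the number follows chain length, and ethyl or propyl there could sit anywhere relative to them. Going by these compounds, whether a chain ending in a hydroxyl group or an acetyl group on the same nitrogen would keep the lower numbers also remains open.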